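The source may report more compounds than this note shows. Statements on the series, on what has been measured and on what is new or still open speak of the compounds shown alone.

Measured compounds:

Compound 1, `COc1ccc(Oc2ccccc2-c2ccsc2S(=O)(=O)N2CCN(C(=S)Nc3ccc([N+](=O)[O-])cc3)CC2)cc1OC`: 16%
Compound 2, `COc1ccc(Oc2ccccc2-c2ccsc2S(=O)(=O)N2CCN(C(=S)Nc3ccc(Cl)cc3)CC2)cc1OC`: 18%
Compound 3, `O=S(=O)(c1sccc1-c1ccccc1Oc1ccc(O)c(O)c1)N1CCN(C(=S)Nc2ccc(Cl)cc2)CC1`: 2%

All three were tested in an assay for binding affinity to Apoptosis regulator Bcl-2 (Homo sapiens), read by fluorescence polarization, with stated times of 30 min and 20 min, tested at 100 uM; on this read-out lower numbers stand for less inhibition and higher numbers for more inhibition at the one concentration tested (going by the name of the read-out). Compound 2 gives 18%, and the closely related compound 1 gives 16%. The two differ only in one group, (nitro in place of chloro on an aromatic carbon), and the step that this change made is a number 2 percentage points lower from compound 2 to compound 1 (within the scatter), so the two readings cannot be told apart.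

Compound 3 shares the same thiourea end with compound 2 but carries a different core; the two cores differ by 3,4-dihydroxyphenyl in place of 3,4-dimethoxyphenyl on an oxygen on an aromatic ring. This change gave a number 16 percentage points lower from compound 2 to compound 3 (beyond the scatter), and compound 3 stands lowest of the three measured compounds in this assay.

Compound 4, `O=[N+]([O-])c1ccc(NC(=S)N2CCN(S(=O)(=O)c3sccc3-c3ccccc3Oc3ccc(O)c(O)c3)CC2)cc1`, has not yet been measured. It stands to compound 3 as compound 1 stands to compound 2: the difference is nitro in place of chloro on an aromatic carbon, at a place described in exactly the same words as before, so it is the same change. From compound 3 to compound 4 a step of no change at the digits printed from compound 3 to compound 4 (within the scatter) is expected, resting on the earlier step of a number 2 percentage points lower from compound 2 to compound 1 (within the scatter), which showed no change worth the name. Because compound 3 gives 2%, compound 4 is estimated at 2% in this assay, with a likely range from -8% to 12%.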

Compound 4, a percentage reported as inhibition, at one concentration (the size of the read-out at that concentration, not a potency): 31%
The estimate for compound 4 lay 29 percentage points below the measured number; measured number above the stated range.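

On the core carrying 3,4-dihydroxyphenyl, nitro in place of chloro gave a number 29 percentage points higher from compound 3 to compound 4 (beyond the scatter), while on the core carrying 3,4-dimethoxyphenyl the same change gave a number 2 percentage points lower from compound 2 to compound 1 (within the scatter), so in this assay this change did not carry from one core to the other: the same change on two cores in this assay, a number 2 percentage points lower (within the scatter) from compound 2 to compound 1 and a number 29 percentage points higher (beyond the scatter) from compound 3 to compound 4, 31 percentage points apart, beyond the scatter of two such steps Seen from the other side, 3,4-dihydroxyphenyl in place of 3,4-dimethoxyphenyl gave a number 15 percentage points higher from compound 1 to compound 4 (beyond the scatter) with nitro present, but a number 16 percentage points lower from compound 2 to compound 3 (beyond the scatter) with chloro present: the same change on two cores in this assay, a number 16 percentage points lower (beyond the scatter) from compound 2 to compound 3 and a number 15 percentage points higher (beyond the scatter) from compound 1 to compound 4, 31 percentage points apart, beyond the scatter of two such steps Within these four compounds, then, the outcome of each change depends on which group sits at the other site, so a step read on one core is a poor guide to the same step on another, but the data do not show why this happens or whether it holds beyond these compounds.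

The compounds shown leave open whether the rise with nitro on the 3,4-dihydroxyphenyl core is special to nitro or would also appear with another group in its place, such as a nitrile or a trifluoromethyl. They also leave open whether both hydroxyl groups are needed for this behaviour, which a ring carrying one hydroxyl and one methoxy could help to settle.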